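The source may report more compounds than this note shows. Statements on the series, on what has been measured and on what is new or still open speak of the compounds shown alone.

Measured compounds:
- compound 1, `O=C(NCc1ccc(CNS(=O)(=O)c2ccccc2Cl)cc1)c1cccnc1`: 100 nM
- compound 2, `COc1ccccc1C(=O)NCc1ccc(CNS(=O)(=O)c2ccc(F)cc2)cc1`: 100 nM

The series is followed in an assay on MDA-MB-231 cells for displacement of a labelled ligand from C-X-C chemokine receptor type 4 (Homo sapiens), read by fluorescence and microscopy, with stated times of 10 min and 30 min; on this read-out lower numbers stand for an effect already at smaller amounts and higher numbers for an effect only at larger amounts of compound. In this assay compound 1 gives 100 nM, and compound 2 gives 100 nM. Among the measured compounds shown here, no step between measured compounds that differ in one place is available, so nothing can be said of the two values beyond what they show: compound 1 stands level with compound 2 at the digits reported, the nearest measured compound, with no change at those digits, within the scatter.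

The unmeasured compound 3, `O=C(NCc1ccc(CNS(=O)(=O)c2ccc(Cl)cc2)cc1)c1cccnc1`, is to be measured in this assay. It differs from compound 1 in one place: 4-chlorophenyl in place of 2-chlorophenyl on a sulfonyl sulfur. The two compounds hold the same atoms, joined differently; the sulfonyl sulfur carries 4-chlorophenyl where compound 1 carries 2-chlorophenyl, and the sulfonamide nitrogen remains its other neighbour.

For the measured compounds named here, with no measured step of this kind on hand, the expected step of a 1.2-fold higher number from compound 1 to compound 3 (0.08 log units; within the scatter) is no change beyond the scatter, in either direction. Going by the values given here, compound 3 is accordingly estimated at 120 nM in this assay, with a range from 40 nM to 400 nM, the width reflecting that the change has no measured counterpart.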

Compound 3, effective concentration (reported as EC, without a stated level of effect): 1000 nM
Compound 3: the middle estimate sits 8.3-fold (0.92 log units) below what was measured; measured number outside the range, above it.
By their numbers in this assay, from the lowest: compounds 1 and 2 (each within the scatter of the next); then compound 3.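

In this assay the swap of 2-chlorophenyl for 4-chlorophenyl on the sulfonyl sulfur gives a 10-fold higher number from compound 1 to compound 3 (1.00 log units; beyond the scatter) with the atoms of the two compounds unchanged, so this position responds to where the chlorine stands on the ring and not only to which atoms are present. Among the compounds shown here, this is the first single-place comparison, as compound 1 and compound 2 differ in more than one place and their matching values could not show what any one group contributes. No measurement at hand bears on the origin of this step, which rests on one pair and has no repeat on a second core.

Going by these compounds, whether an unsubstituted phenyl or a 3-chlorophenyl on the sulfonyl sulfur would fall nearer compound 1 or compound 3 remains open, as does whether a methyl or a methoxy group in place of the chlorine would follow the same order. Also open, on these data alone, is whether the same preference holds when the pyridine-bearing amide end of compound 1 is replaced, for example by a piperidine or a carboxylic acid.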